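A few compounds are considered here, and "the series" means these few. Any claim that something is new, unique, unknown or untested is made for them only; others in the source may bear on it.

Of the compounds shown here, two of a shared core have so far been measured in a physicochemical assay for lipophilicity; a higher number here means a more lipophilic compound, a lower number a more polar compound. Compound 1 `CCN(Cc1ccccc1)c1ccc(C(=O)N2CCc3ccc(OS(N)(=O)=O)cc3C2)cc1` gives 3.08, and compound 2 `CCCN(Cc1ccccc1)c1ccc(C(=O)N2CCc3ccc(OS(N)(=O)=O)cc3C2)cc1` gives 1.93, the lower of the two numbers. Among the measured compounds shown here, the only measured step, a number 1.15 log units lower from compound 1 to compound 2 (beyond the scatter), is large and goes against the usual trend for an added carbon. Compound 3 `NS(=O)(=O)Oc1ccc2c(c1)CN(C(=O)c1ccc(N(Cc3ccccc3)Cc3ccco3)cc1)CC2` differs from compound 2 by furan-2-yl in place of ethyl on a saturated chain carbon bound to a nitrogen on an aromatic ring. For the measured compounds named here, no measured step covers such a ring, so the one measured step gives only a caution. The estimated step of a number 0.47 log units higher from compound 2 to compound 3 (beyond the scatter) rests on that, and compound 3 is expected to give about 2.4, between 1.4 and 3.4.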

Compound 3, partition coefficient: 1.93
Compound 3: the middle estimate sits 0.47 log units above what was measured, within the range that was stated.
By their numbers in this assay, from the lowest: compounds 2 and 3 (each within the scatter of the next); then compound 1.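

In this assay, furan-2-yl in place of ethyl gives no change at the digits printed from compound 2 to compound 3 (within the scatter) at this place, so a five-membered aromatic ring with an oxygen reads the same here as the two-carbon group. Set against methyl, the same ring gives a number 1.15 log units lower from compound 1 to compound 3 (beyond the scatter) and is a large step, which shows that the low number is not unique to compound 2 and leaves compound 1 alone at the high end. Nothing measured here explains this. From the compounds shown here alone, whether a longer chain such as butyl, or an amine, would stay with compound 2 and compound 3 or with compound 1 remains open.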